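Trading a Ring Fragment for an Open Chain

This account rests on a few compounds, and the source may have more. Where it says the series, first, only, none or still open, it means among the compounds named here.

Compound 1, `CCCCCCCCCO[C@@H]1[C@@H](N)[C@@H](O[C@H]2[C@H](O)[C@@H](O)[C@H](N)C[C@@H]2N)O[C@H](CN)[C@H]1OCCCCCCCCC`, opens the pair of measured compounds. Among the measured compounds shown here, in a toxicity assay on the whole organism (J774 cells) for cytotoxicity, with Mus musculus as the target, read by MTT assay, with a stated time of 24 h, tested at 30 uM (a higher number here means a weaker effect of the compound at the concentration tested, a lower number a stronger effect), compound 1 gives 48.6%, the higher of the two numbers so far. Compound 2, `C=CCO[C@H]1O[C@H](CN)[C@@H](OCc2ccc3ccccc3c2)[C@H](OCc2ccc3ccccc3c2)[C@H]1N`, sits well apart: in this assay compound 2 gives 28.3%, a gap beyond the usual scatter, so compound 1 shows the weaker effect of the two. These two differ in many places at once, so no single step can be read from them.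

Compound 3, `CCCCCCCCCO[C@@H]1[C@@H](N)[C@@H](OCC(O)CNCCN)O[C@H](CN)[C@H]1OCCCCCCCCC`, has not been measured. It differs from compound 1 in one place: 3-((2-aminoethyl)amino)-2-hydroxypropyl in place of 4,6-diamino-2,3-dihydroxycyclohexyl on an oxygen on a saturated carbon. For the measured compounds named here, no measured pair shows a change of this kind, so its size has to be judged without precedent. The expected step from compound 1 to compound 3 is a number 4.6 percentage points lower from compound 1 to compound 3 (within the scatter), in no clear direction beyond the scatter. Compound 3 is therefore estimated to give about 44% in this assay, within a likely range from 22% to 68%.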

Compound 3, a percentage reported as activity, at one concentration (the size of the read-out at that concentration, not a potency): 53%
Compound 3: middle estimate off by 9 percentage points, on the low side; measured number inside the range.
By their numbers in this assay, from the lowest: compound 2; then compounds 1 and 3 (each within the scatter of the next).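

The ring of 4,6-diamino-2,3-dihydroxycyclohexyl, on an oxygen on a saturated carbon, can be replaced by the open chain 3-((2-aminoethyl)amino)-2-hydroxypropyl without a change that can be told from the scatter in this assay: the step is a number 4.4 percentage points higher from compound 1 to compound 3 (within the scatter). Among the compounds shown here, at this position, then, the carbon ring itself is not needed to keep the read-out of compound 1, and this is the first single-place change that shows it. No measurement here explains why the two groups read alike.

This is one replacement at one position, in one assay, so it cannot be extended to other groups. Going by these compounds, how a longer chain, a carboxylic acid or a single primary amine at this place would read remains open.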